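Cytotoxicity of Quinolone Esters in HepG2 Cells

The compounds below may be only part of what the source reports. "The series", "measured", "known", "first", "only" and "open" are said of these compounds alone.

Three quinolone esters were examined in an ADME assay on HepG2 cells (Homo sapiens) for cytotoxicity, read by luminescence, with a stated time of 72 h; a lower number here means that less compound is needed, a higher number that more compound is needed for the effect. Compound 1, whose structure is `CCOC(=O)c1c(-c2cccc(-c3ccccc3)c2)[nH]c2cc(OC)ccc2c1=O`, carries a phenyl group on the pendant aromatic ring. In this assay compound 1 gives only a limit, namely > 21500 nM. Compound 2, `CCOC(=O)c1c(-c2cccc(OC)c2)[nH]c2cc(OC)ccc2c1=O`, replaces that phenyl with a methoxy group (methoxy in place of phenyl on an aromatic carbon). In this assay compound 2 likewise reaches only a limit, > 21500 nM. The step that the two limits leave unreadable from compound 1 to compound 2 therefore cannot be sized, because of the limit of > 21500 nM in this assay, at which 3 of the 3 values shown sit.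

Compound 3, `CCOC(=O)c1c(-c2cccc(-c3ccccc3)c2)[nH]c2cc(Cl)c(OC)cc2c1=O`, keeps the phenyl group of compound 1 but has a different core; the difference between the two cores is not broken down here. In this assay compound 3 also stops at a limit, > 21500 nM.

Compound 4, `CCOC(=O)c1c(-c2cccc(OC)c2)[nH]c2cc(Cl)c(OC)cc2c1=O`, has not yet been measured in this assay. It stands to compound 3 exactly as compound 2 stands to compound 1: a methoxy in place of phenyl on an aromatic carbon, the same change at the same kind of place. Since the step from compound 1 to compound 2 left both values at the limit, and compound 3 itself sits at that limit, the step that the limit leaves unreadable from compound 3 to compound 4 is expected to be no more readable than the earlier one. Compound 4 is accordingly estimated at 35000 nM, within a range from 15000 nM to 120000 nM, and most likely the assay will again report only a limit.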

Compound 4, half-maximal effective concentration: > 21500 nM
Compound 4: only a limit was reported; the forecaster's own chance of this, stated with the estimate: 85%; the middle value does not contradict the limit.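

In this assay compound 4 gives > 21500 nM, which is a limit and not a number. No step can therefore be read between compound 3 and compound 4, because neither compound has a value beyond the limit: the limit of > 21500 nM in this assay, at which 4 of the 4 values shown sit.

The compounds shown leave open what concentration any of them needs for the effect, and whether exchanging phenyl for methoxy changes it at all.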